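The compounds below may be only part of what the source reports. "The series", "measured", "known", "first", "only" and "open" are said of these compounds alone.

Of the compounds shown here, two have so far been measured in an ADME assay on S9 fraction from liver (Rattus norvegicus) for metabolic stability, read by LC-MS, using NADPH, with a stated time of 90 min, tested at 5 uM; a higher number here means that more of the compound is left, a lower number that less of the compound is left. Compound 1, `Cn1c(Sc2c(F)cc(C(=O)NO)cc2F)nnc1-c1cccs1`, gives 71% in this assay, the higher of the two numbers. Compound 2, `Nc1ccc(-c2nnn(Cc3c(F)cc(C(=O)NO)cc3F)n2)cc1`, gives 48% in this assay, a number lower than that of compound 1 by more than the usual scatter. Going by the values given here, compound 2 differs from compound 1 in more than one place at once, so no single step between measured compounds can be read from these two values.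

Compound 3, `Cc1cc(-c2nnc(Sc3c(F)cc(C(=O)NO)cc3F)n2C)nn1C`, has not yet been measured. Among the compounds with values here, it differs from compound 1 in one place: 1,5-dimethyl-1H-pyrazol-3-yl in place of thiophen-2-yl on an aromatic carbon None of the measured compounds shows what this change does in this assay, so no direction can be taken from the data. The expected step is therefore small, within the scatter or close to it: a number 6 percentage points lower from compound 1 to compound 3 (within the scatter). Compound 3 is estimated at 65%, with a range from 40% to 88%.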

Compound 3, percent of the compound remaining: 30%
Beside the measured number, compound 3's estimate is 35 percentage points above it; measured number outside the range, below it.
By their numbers in this assay, from the lowest: compound 3; then compound 2; then compound 1.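

In this assay, replacing thiophen-2-yl with 1,5-dimethyl-1H-pyrazol-3-yl gives a number 41 percentage points lower from compound 1 to compound 3 (beyond the scatter), so the amount of compound left depends strongly on what this aromatic carbon of the five-membered ring with 3 nitrogen carries. Going by these compounds alone, this is the first single change that can be read here, as compound 1 and compound 2 differ in more than one place at once. No measurement at hand explains the step.

The compounds shown leave open whether the ring nitrogen atoms or the two methyl groups of the new ring matter more, as both enter together in this one change. They also leave open how the same position would respond to a plain phenyl ring, a furan-2-yl group or a pyrazole ring without methyl groups.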